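Removing the fluoro from compound 2

The source may report more compounds than this note shows. Statements on the series, on what has been measured and on what is new or still open speak of the compounds shown alone.

Measured in a functional assay on MCF7 cells (Homo sapiens) for antiproliferative activity, read by MTT assay, with a stated time of 72 h; on this read-out lower numbers stand for stronger inhibition and higher numbers for weaker inhibition:
- Compound 1 `O=C(N/N=C/c1cccn1CCCN1CCCCC1)Nc1ccc(Oc2ccnc3[nH]ccc23)c(F)c1`: 4840 nM
- Compound 2 `CN1CCN(CCCn2cccc2/C=N/NC(=O)Nc2ccc(Oc3ccnc4[nH]ccc34)c(F)c2)CC1`: 3740 nM

Going by the values given here, compound 2 cannot be separated from compound 1 on these numbers, since the only measured step is a 1.3-fold lower number from compound 1 to compound 2 (0.11 log units; within the scatter). Compound 3 `CN1CCN(CCCn2cccc2/C=N/NC(=O)Nc2ccc(Oc3ccnc4[nH]ccc34)cc2)CC1` has hydrogen in place of fluoro on an aromatic carbon of compound 2: hydrogen in place of fluoro on an aromatic carbon. The measured step swaps a group on a chain carbon and leaves the fluoro untouched, so no measurement tests this change. With no evidence for a shift, no step beyond the scatter is expected in this assay. Compound 3 is estimated at 4000 nM, with an expected range of 1600 nM to 10000 nM. This estimate means an expected 1.1-fold higher number from compound 2 to compound 3 (0.03 log units; within the scatter).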

Compound 3, half-maximal inhibitory concentration: 4280 nM
The estimate for compound 3 lay 1.1-fold (0.03 log units) below the measured number; low and high end bracket the measured number.
By their numbers in this assay, from the lowest: compounds 2, 3 and 1 (each within the scatter of the next).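

In this assay, replacing the fluoro on this aromatic carbon, ortho to a large group and meta to a large group, with hydrogen gives a 1.1-fold higher number from compound 2 to compound 3 (0.06 log units; within the scatter). Going by these compounds alone, this is the first test of the change, and on these numbers the two compounds cannot be told apart, so the fluoro is not needed here to keep this level of activity. Nothing measured here offers an explanation for the result. Still open, as far as these compounds go, is whether a larger group at this carbon, such as chloro or methoxy, would separate from hydrogen. Also open, from the compounds shown here alone, is whether removing the fluoro gives the same result alongside the piperidin-1-yl group of compound 1.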